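The compounds below may be only part of what the source reports. "The series", "measured", "known", "first", "only" and "open" are said of these compounds alone.

Compound 2 `CCc1ccc(-n2nc(-c3ccccc3)nc2CNc2ccc(C(=O)NO)cc2)cc1` and compound 4 `O=C(NO)c1ccc(NCc2nc(-c3ccccc3)nn2-c2ccc(F)cc2)cc1` share one core, and in an assay on Sf9 cells for inhibition of protein deacetylase HDAC6 (Homo sapiens), read by fluorescence, with a stated time of 40 min, tested at 100 nM (on this read-out higher numbers stand for more inhibition at the one concentration tested (going by the name of the read-out) and lower numbers for less inhibition), compound 2 gives 38.3%, the second highest of three numbers: compound 3 `O=C(NO)c1ccc(NCc2nc(-c3ccc(Cl)c(Cl)c3)nn2-c2ccccc2)cc1`, at 34.5%, lies within the scatter of it, while compound 1 `O=C(NO)c1ccc(NCc2nc(-c3cccnc3)nn2-c2ccccc2)cc1`, at 57.7%, stands beyond the scatter above it. The change to compound 4 is fluoro in place of ethyl on an aromatic carbon. For the measured compounds named here, no measured step touches this ring: the only step, a number 23.2 percentage points lower from compound 1 to compound 3 (beyond the scatter), concerns a different aryl group and so gives no direct guide. With nothing pointing in either direction, a change no larger than the scatter is expected, and the estimated step is a number 2.3 percentage points lower from compound 2 to compound 4 (within the scatter). Compound 4 is therefore expected to give about 36%, between 20% and 55%.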

Compound 4, a percentage reported as inhibition, at one concentration (the size of the read-out at that concentration, not a potency): 67.6%
The estimate for compound 4 lay 31.6 percentage points below the measured number; the measured number lies above the stated range.
By their numbers in this assay, from the lowest: compounds 3 and 2 (each within the scatter of the next); then compounds 1 and 4 (each within the scatter of the next).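

In this assay, for the compounds shown here, the change from 4-ethylphenyl to 4-fluorophenyl brings a number 29.3 percentage points higher from compound 2 to compound 4 (beyond the scatter) and so shows that this ring position, which no earlier step touched, responds to the group it carries. In this single pair, fluoro, with one heavy atom, gives the higher number and ethyl, with two, the lower. No measured evidence accounts for the step.

As far as these compounds go, how a chloro, a methoxy or an amine at this place would compare remains open. So does whether the step holds with the pyridin-3-yl of compound 1 on the core.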